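The compounds below may be only part of what the source reports. "The series", "measured", "known", "first", "only" and "open" are said of these compounds alone.

Compound 1 `O=C1C(O)=C(C(c2ccc([N+](=O)[O-])cc2)c2c[nH]c3ccccc23)C(=O)c2ccccc21` in a toxicity assay (Homo sapiens) for cytotoxicity, read by MTT assay, with a stated time of 48 h; a lower number here means a stronger inhibitor, a higher number a weaker inhibitor: > 200000 nM, which is a limit of the assay rather than a number.
Compound 2 `O=C1C(O)=C(C(c2cccc([N+](=O)[O-])c2)c2c[nH]c3ccccc23)C(=O)c2ccccc21` in this assay: 91200 nM.
Compound 3 `O=C1C(O)=C(C(c2ccc(Cl)cc2)c2c[nH]c3ccccc23)C(=O)c2ccccc21` in this assay: 102000 nM.

Compound 1 therefore stands only at a limit, with no number of its own, as the limit of > 200000 nM in this assay, at which 1 of the 3 values shown sits, records. The measured steps, an at least 2.1-fold lower number from compound 1 to compound 2 (0.34 log units; beyond the scatter) and an at least 1.9-fold lower number from compound 1 to compound 3 (0.29 log units; that floor lies within the scatter), both alter the nitrophenyl side of the shared core. Going by the values given here, the change to compound 4 `O=C1C(O)=C(C(c2ccc([N+](=O)[O-])cc2)c2c[nH]c3ccc(Br)cc23)C(=O)c2ccccc21` is different: bromo in place of hydrogen on an aromatic carbon, on the indole part, which no measured step tests. With nothing bearing on it, no step beyond the scatter is expected, an at least 1.3-fold lower number from compound 1 to compound 4 (0.12 log units; that floor lies within the scatter). Compound 4 is accordingly estimated at 150000 nM, within 60000 nM to 300000 nM, and may again be reported only as a limit.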

Compound 4, half-maximal inhibitory concentration: 45200 nM
Compound 4: the middle estimate sits 3.3-fold (0.52 log units) above what was measured; the measured number lies below the stated range.
By their numbers in this assay, from the lowest: compounds 4, 2 and 3 (each within the scatter of the next, the first and the last beyond it). At a limit, above all of these: compound 1.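

In this assay, going by these compounds alone, 5-bromo-1H-indol-3-yl in place of 1H-indol-3-yl gives an at least 4.4-fold lower number from compound 1 to compound 4 (0.64 log units; beyond the scatter) on the indole part of the shared core, which no earlier compound had changed. A single change away from the nitrophenyl side can therefore also move the number beyond the scatter. The full size of this step stays unknown because compound 1 has only a limit and no number of its own: the limit of > 200000 nM in this assay, at which 1 of the 4 values shown sits.

As far as these compounds go, whether chloro, a methoxy group or an amine on this same aromatic carbon would give a similar step remains open. So does whether bromo here would act alike with the 3-nitrophenyl of compound 2 or the 4-chlorophenyl of compound 3.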